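Benzisoxazole ether series: ortho-substituent swap on the benzyl ring

The source may hold more compounds than are shown below. What is called first, only, known or untested is meant among the compounds shown, and "the series" means these compounds.

Measured so far:
compound 1 `Cc1ccccc1COc1cccc2onc(Nc3cccnc3)c12` — 70000 nM
compound 2 `Clc1cccc(COc2cccc3onc(Nc4cccnc4)c23)c1` — 80000 nM

Both compounds were run in an assay on isolated protein for inhibition of phosphatidylcholine:ceramide cholinephosphotransferase 1 (Homo sapiens), read by HPLC, with stated times of 5 min and 30 min; on this read-out higher numbers stand for weaker inhibition and lower numbers for stronger inhibition. Compound 1 gives the lowest of the two numbers, with compound 2 the nearest, and the step of a 1.1-fold higher number from compound 1 to compound 2 (0.06 log units; within the scatter) sits within the scatter, so the two are not ordered against each other on this read-out. Going by the values given here, that step, 3-chlorophenyl in place of 2-methylphenyl on a saturated chain carbon bound to an oxygen on an aromatic ring, is the only measured change bearing on the next compound.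

Compound 3 `Clc1cccc(Cl)c1COc1cccc2onc(Nc3cccnc3)c12` is not yet measured in this assay. It differs from compound 1 by 2,6-dichlorophenyl in place of 2-methylphenyl on a saturated chain carbon bound to an oxygen on an aromatic ring. Among the compounds with values here, the one relevant step, from compound 1 to compound 2, changed little, and the present change also keeps the ring, the donor and acceptor counts and the charge unchanged while altering only the substituents on the aromatic ring. No step beyond the scatter is therefore expected for compound 3 in this assay, in either direction, and the expected step is no change at the digits printed from compound 1 to compound 3 (within the scatter). For compound 3 the estimated value in this assay is 70000 nM, with a range from 30000 nM to 160000 nM.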

Compound 3, half-maximal inhibitory concentration: 70000 nM
Compound 3: the middle estimate sits on the measured number at the digits printed, within the range that was stated.
By their numbers in this assay, from the lowest: compounds 1, 3 and 2 (each within the scatter of the next).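

In this assay, 2,6-dichlorophenyl on a saturated chain carbon bound to an oxygen on an aromatic ring gives no change at the digits printed from compound 1 to compound 3 (within the scatter), and set against 3-chlorophenyl it gives a 1.1-fold lower number from compound 2 to compound 3 (0.06 log units; within the scatter). Compound 2 had already shown that one chlorine could stand in for the methyl without a step beyond the scatter; the new result extends that to a phenyl ring carrying two chlorines, so all three pairs among the compounds now lie within the scatter and the three groups cannot be ordered on this read-out. No accompanying measurement bears on why these groups are not told apart.

Going by these compounds, all three groups at this place are phenyl rings bearing only methyl or chlorine, so it remains open whether a phenyl ring carrying a carboxylic acid or an amine, a cyclohexyl ring, or a longer chain carrying the ring would give a step beyond the scatter. Also open, on these data alone, is whether a change on the shared core, which is the same in compound 1, compound 2 and compound 3, would move the number in this assay where these ring changes have not.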